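Replacing the hydroxyphenyl amide in a triazole-linked series

The compounds below may be only part of what the source reports. "The series", "measured", "known", "first", "only" and "open" are said of these compounds alone.

Compounds measured:
compound 1 `CC(C)COc1ccc(NC(=O)CCCCCCCSc2nnc(Cc3nn(C)c(=O)c4ccccc34)n2C)cc1`, 4800 nM
compound 2 `Cn1c(Cc2nn(C)c(=O)c3ccccc23)nnc1SCCCCCCCC(=O)Nc1ccccc1O`, 27000 nM

In an assay on isolated protein (Mus musculus) for inhibition of IL15-IL15 receptor (Homo sapiens), read by resazurin assay, with stated times of 30 min and 2.5 days (a lower number here means a stronger inhibitor, a higher number a weaker inhibitor), compound 2 gives the highest of the two numbers shown; its nearest neighbour is compound 1, and the step of a 5.6-fold higher number from compound 1 to compound 2 (0.75 log units; beyond the scatter) lies beyond the scatter. Compound 3 `CN(C(=O)CCCCCCCSc1nnc(Cc2nn(C)c(=O)c3ccccc23)n1C)c1ccc(Cl)cc1Cl` differs from compound 2 by (2,4-dichlorophenyl)(methyl)amino in place of (2-hydroxyphenyl)amino on a carbonyl carbon. Among the compounds with values here, no measured step covers this change; only the step from compound 1 to compound 2 shows that altering this amide substituent moves this assay by a modest amount. Compound 3 is therefore expected to come in lower than compound 2, with an estimated step of a 2.7-fold lower number from compound 2 to compound 3 (0.43 log units; beyond the scatter), giving an estimate of 10000 nM with a range from 3000 nM to 40000 nM.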

Compound 3, half-maximal inhibitory concentration: 11900 nM
For compound 3 the middle estimate is 1.2-fold (0.08 log units) below the measured one; the range from low to high includes it.
By their numbers in this assay, from the lowest: compound 1; then compound 3; then compound 2.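

In this assay, a 2.3-fold lower number from compound 2 to compound 3 (0.36 log units; beyond the scatter) shows that a group with no hydrogen-bond donors can stand on this carbonyl carbon without loss against (2-hydroxyphenyl)amino. The amide hydrogen is therefore not needed for the lower number, yet a 2.5-fold higher number from compound 1 to compound 3 (0.39 log units; beyond the scatter) leaves (2,4-dichlorophenyl)(methyl)amino short of (4-(isobutoxy)phenyl)amino. Nothing given here accounts for either step. From the compounds shown here alone, the methyl on the amide nitrogen and the two chlorines enter together, so their separate shares stay open. Going by these compounds, how a saturated amine such as piperidine would read on this carbonyl carbon also remains open.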